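The compounds below may be only part of what the source reports. "The series", "measured", "known", "first", "only" and "open" are said of these compounds alone.

Working notes on a small set of diamino-triazines carrying a substituted phenyl ring, all examined in a functional assay on the whole organism with Rattus norvegicus as the target, at a dose of 20 mg/kg by the intraperitoneal route; a higher number here means more inhibition at the dose given (going by the name of the read-out), a lower number less inhibition.

Compound 1 `Nc1nc(N)nc(-c2ccccc2Br)n1` carries a bromo group on the phenyl ring; in this assay compound 1 gives 26%. Compound 3 `Nc1nc(N)nc(-c2ccc(F)cc2)n1` carries a fluoro group instead; in this assay compound 3 gives 84%. Compound 2 `COc1ccc(Br)cc1-c1nc(N)nc(N)n1` carries both a methoxy and a bromo group; in this assay compound 2 gives 49%. Among the three numbers, compound 2 stands second highest: the nearest value is that of compound 1, lower by a gap that lies beyond the usual scatter, and the furthest is that of compound 3, higher by a gap that also lies beyond the scatter.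

Compound 4 `Nc1nc(N)nc(-c2cc(Br)ccc2Cl)n1` has not been measured in this assay. It differs from compound 2 in one place: chloro in place of methoxy on an aromatic carbon on an aromatic carbon of a six-membered aromatic ring of carbon only, ortho to a group of 8 heavy atoms and para to a bromo group. Among the compounds with values here, no directly comparable step between measured compounds exists, so the direction must be inferred. A moderate decrease is expected, a step of about a number 14 percentage points lower from compound 2 to compound 4 (beyond the scatter), because compound 1, which also carries a halogen on the ring and no methoxy, gives 26%. For compound 4 the estimated inhibition is 35%, within a range from 15% to 60%.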

Compound 4, a percentage reported as inhibition, in the whole organism at one dose (the size of the read-out at that dose, not a potency): 86%
Compound 4: middle estimate off by 51 percentage points, on the low side; measured number above the stated range.
By their numbers in this assay, from the lowest: compound 1; then compound 2; then compounds 3 and 4 (each within the scatter of the next).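

In this assay, within the data shown here, chloro in place of methoxy on this aromatic carbon, ortho to a group of 8 heavy atoms and para to a bromo group, gives a large step, a number 37 percentage points higher from compound 2 to compound 4 (beyond the scatter), and this is the first comparison in which only one place changes. With the bromo group and the rest of the structure held constant, the read-out is clearly sensitive to what this position carries, and the presence of the bromo group does not by itself hold the number down, since compound 4 gives 86%. The data offer no measurement that bears on why the two groups differ so sharply.

From the compounds shown here alone, whether the high number belongs to chloro specifically or simply follows the loss of methoxy remains open, and a hydrogen, a methyl, a hydroxyl or an amine at this position would help separate the two readings. It is also open whether the same exchange would give a step of similar size without the bromo group, as no pair among these compounds tests this.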